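Rat microsome half-life: ester chain variants of compound 2

This account rests on a few compounds, and the source may have more. Where it says the series, first, only, none or still open, it means among the compounds named here.

Measured so far:
compound 1 `CCOC(=O)/C=C/c1ccc(NC(=O)C2(NC(=O)c3ccc4c(C5CCCC5)c(-c5ncc(Cl)cn5)n(C)c4c3)CCC2)cc1OCC` — 3.07 h
compound 2 `CCCOC(=O)/C=C/c1ccc(NC(=O)C2(NC(=O)c3ccc4c(C5CCCC5)c(-c5ncc(Cl)cn5)n(C)c4c3)CCC2)cc1OCC` — 0.35 h
compound 3 `CCOc1cc(NC(=O)C2(NC(=O)c3ccc4c(C5CCCC5)c(-c5ncc(Cl)cn5)n(C)c4c3)CCC2)ccc1/C=C/C(=O)OCCOCCOC` — 1.07 h

All three share one core and differ only in the ester chain. In an ADME assay (liver) for pharmacokinetics, with Liver microsome (Rattus norvegicus) as the target, using microsomes (a higher number here means that the compound lasts longer, a lower number that the compound disappears faster), compound 2 gives 0.35 h, the lowest of the three numbers; the step of an 8.8-fold lower number from compound 1 to compound 2 (0.94 log units; beyond the scatter) and the step of a 3.1-fold higher number from compound 2 to compound 3 (0.49 log units; beyond the scatter) both lie beyond the scatter, so compound 2 stands clearly below compound 1 and below compound 3.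

Compound 4 `CCOc1cc(NC(=O)C2(NC(=O)c3ccc4c(C5CCCC5)c(-c5ncc(Cl)cn5)n(C)c4c3)CCC2)ccc1/C=C/C(=O)OCC(=O)N(C)C(C)C` is not yet measured. Relative to compound 2 the change is isopropyl(methyl)carbamoyl in place of ethyl on a saturated chain carbon bound to an oxygen next to a carbonyl group.

The step that bears most directly is a 3.1-fold higher number from compound 2 to compound 3 (0.49 log units; beyond the scatter), where a larger chain in place of methyl at a nearby carbon raised the number. The step of a 2.9-fold lower number from compound 1 to compound 3 (0.46 log units; beyond the scatter) shows that this larger chain still sits below the plain ethyl ester of compound 1. Taken together, a modest rise from compound 2 is expected, roughly of the size seen in the step to compound 3, so compound 4 is estimated at 1 h with a range from 0.4 h to 2.5 h. The step of a 2.9-fold higher number from compound 2 to compound 4 (0.46 log units; beyond the scatter) is the expected change, not a measured one.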

Compound 4, half-life: 0.267 h
Estimate against measurement, compound 4: 3.7-fold (0.57 log units) above; measured number outside the range, below it.
By their numbers in this assay, from the lowest: compounds 4 and 2 (each within the scatter of the next); then compound 3; then compound 1.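

On the saturated chain carbon bound to an oxygen next to a carbonyl group, the step of a 1.3-fold lower number from compound 2 to compound 4 (0.12 log units; within the scatter) stays within the scatter in this assay and does not separate the isopropyl(methyl)carbamoyl chain from the propyl ester. The step of a 4.0-fold lower number from compound 3 to compound 4 (0.60 log units; beyond the scatter) shows that the rise seen with the 2-methoxyethoxy chain does not carry over to this carbamoyl chain, so a longer ester chain alone does not set the number. The step of an 11-fold lower number from compound 1 to compound 4 (1.06 log units; beyond the scatter) is the largest in the set and places all three other ester chains under the ethyl ester of compound 1.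

Still open, as far as these compounds go, is how a methyl ester or the free carboxylic acid at this place would stand against compound 1. No measured evidence is available to explain these differences.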